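The compounds below may be only part of what the source reports. "The series", "measured", "known", "first", "only" and "open" are said of these compounds alone.

Measured compounds in an ADME assay on Vero cells (Chlorocebus sabaeus) for cytotoxicity, read by MTT assay, with a stated time of 72 h; on this read-out higher numbers stand for weaker inhibition and lower numbers for stronger inhibition:
compound 1 `CC(=O)N1N=C(c2ccc(-n3c(C)ccc3C)cc2)OC1c1ccccc1Cl`: 201000 nM
compound 2 `CC(=O)N1N=C(c2ccc(-n3c(C)ccc3C)cc2)OC1c1ccc(N(C)C)cc1`: 175000 nM
compound 3 `CC(=O)N1N=C(c2ccc(-n3c(C)ccc3C)cc2)OC1c1ccccc1`: 190000 nM

Compound 3 stands second highest of the three numbers, with a 1.1-fold lower number from compound 1 to compound 3 (0.02 log units; within the scatter) and a 1.1-fold higher number from compound 2 to compound 3 (0.04 log units; within the scatter) both within the scatter, so the three compounds are not separable in this assay.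

Compound 4 `CC(=O)N1N=C(c2ccc(-n3c(C)ccc3C)cc2)OC1c1cccc([N+](=O)[O-])c1` differs from compound 3 in one place: nitro in place of hydrogen on an aromatic carbon. Within the data shown here, the steps that bear on it are those altering the same phenyl on the saturated ring carbon: a 1.1-fold lower number from compound 1 to compound 3 (0.02 log units; within the scatter), a 1.1-fold higher number from compound 2 to compound 3 (0.04 log units; within the scatter) and a 1.1-fold lower number from compound 1 to compound 2 (0.06 log units; within the scatter), each within the scatter. No step beyond the scatter is therefore expected from compound 3 to compound 4 in this assay, i.e. no change at the digits printed from compound 3 to compound 4 (within the scatter). Compound 4 is estimated at 190000 nM, range 100000 nM to 360000 nM.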

Compound 4, half-maximal inhibitory concentration: 188000 nM
The estimate for compound 4 lay 1.0-fold (0.00 log units) above the measured number, within the range that was stated.
By their numbers in this assay, from the lowest: compounds 2, 4, 3 and 1 (each within the scatter of the next).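

In this assay, nitro on this aromatic carbon, meta to a large group, gives a 1.0-fold lower number from compound 3 to compound 4 (0.00 log units; within the scatter), and the comparisons with the substituted phenyls, a 1.1-fold higher number from compound 2 to compound 4 (0.03 log units; within the scatter) and a 1.1-fold lower number from compound 1 to compound 4 (0.03 log units; within the scatter), also stay within the scatter. 3-nitrophenyl on the saturated ring carbon therefore cannot be told apart from phenyl, 2-chlorophenyl or 4-(dimethylamino)phenyl in this read-out. No measurement at hand accounts for this lack of separation.

Going by these compounds, whether a carboxylic acid or a primary amine on this phenyl would also stay within the scatter remains open. All four compounds share the rest of the core, so the effect of changes there is open too.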